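The source may report more compounds than this note shows. Statements on the series, on what has been measured and on what is new or still open speak of the compounds shown alone.

In an assay on VSM-A10 cells for antagonist activity at Endothelin-1 receptor (Rattus norvegicus) (a higher number here means a weaker inhibitor, a lower number a stronger inhibitor), compound 1 `Cc1noc(NS(=O)(=O)c2ccc(NC(=O)CN)cc2)c1C` gives 6500 nM, compound 2 `Cc1noc(NS(=O)(=O)c2cccc3c(N4CCCC4=O)cccc23)c1C` gives 130 nM, and compound 3 `Cc1noc(NS(=O)(=O)c2ccc(NCC(=O)O)cc2)c1C` gives 12000 nM.

Compound 2 has the lowest number of the three, and its gaps to compound 1 and to compound 3 both lie beyond the scatter. Compound 4 `Cc1noc(NS(=O)(=O)c2cccc3c(CN(C)C)cccc23)c1C` differs from compound 2 in one place: (dimethylamino)methyl in place of 2-oxopyrrolidin-1-yl on an aromatic carbon. Among the measured compounds shown here, no measured step covers this kind of change. For the measured compounds named here, the only one-place step available, a 1.8-fold higher number from compound 1 to compound 3 (0.27 log units; within the scatter), concerns a different core and different groups, so it gives no direct guide here. Going by the values given here, with no close precedent, a modest move toward a higher number is expected, a 3.1-fold higher number from compound 2 to compound 4 (0.49 log units; beyond the scatter) in this assay. Compound 4 is therefore estimated at 400 nM, with a range from 100 nM to 2500 nM.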

Compound 4, half-maximal inhibitory concentration: 2800 nM
Beside the measured number, compound 4's estimate is 7.0-fold (0.85 log units) below it, and the stated range ends below it.
By their numbers in this assay, from the lowest: compound 2; then compound 4; then compounds 1 and 3 (each within the scatter of the next).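

In this assay the change to (dimethylamino)methyl on this aromatic carbon gives a 22-fold higher number from compound 2 to compound 4 (1.33 log units; beyond the scatter) and so shows that the group held here matters greatly on this core. Among the compounds shown here, the only earlier step concerned a different place on a different core and stayed within the scatter. Nothing measured here says why the number rises. From the compounds shown here alone, it remains open whether a pyrrolidine ring without the carbonyl, an open-chain acetamide or a carboxylic acid at this carbon would stay close to compound 2. Going by these compounds, whether (dimethylamino)methyl would have as large an effect on the core of compound 1 is also open.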